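A few compounds are considered here, and "the series" means these few. Any claim that something is new, unique, unknown or untested is made for them only; others in the source may bear on it.

Measured so far in a functional assay on U2OS cells (Homo sapiens) for antiproliferative activity, read by MTT assay, with a stated time of 72 h (on this read-out higher numbers stand for weaker inhibition and lower numbers for stronger inhibition), are two compounds:
- compound 1 `O=C(CSc1nc2ccccc2[nH]1)Nc1ccc2nc(NC(=O)c3ccc(C(F)(F)F)cc3)sc2c1` gives 7110 nM in this series
- compound 2 `O=C(CSc1ccc2ccccc2c1)Nc1ccc2nc(NC(=O)c3ccc(C(F)(F)F)cc3)sc2c1` gives 3940 nM in this series

Compound 2 stands within the scatter of compound 1, so the two are not ranked. Compound 3 `O=C(CSc1ccc(Cl)cc1)Nc1ccc2nc(NC(=O)c3ccc(C(F)(F)F)cc3)sc2c1` is the next to be read, with 4-chlorophenyl in place of naphthalen-2-yl on a sulfur and the rest of compound 2 unchanged. Among the compounds with values here, the one measured step on that sulfur is a 1.8-fold lower number from compound 1 to compound 2 (0.26 log units; within the scatter) and it is the only evidence bearing on this change. Within the data shown here, no measured compound carries 4-chlorophenyl, so this is a thin basis. Given that single small step, no change beyond the scatter is expected in this assay here. The expected step is a 1.3-fold higher number from compound 2 to compound 3 (0.10 log units; within the scatter) and no direction is claimed for it. For compound 3 the expected value is 5000 nM with an estimated range of 2000 nM to 12000 nM once measured.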

Compound 3, half-maximal inhibitory concentration: 2890 nM
For compound 3 the middle estimate is 1.7-fold (0.24 log units) above the measured one, and the stated range covers the measured number.
By their numbers in this assay, from the lowest: compounds 3, 2 and 1 (each within the scatter of the next, the first and the last beyond it).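

In this assay, 4-chlorophenyl on this sulfur, with one six-membered aromatic ring of carbon only, takes the place of naphthalen-2-yl, with two, and the step is a 1.4-fold lower number from compound 2 to compound 3 (0.13 log units; within the scatter), so on these compounds the second ring is not required to keep the read-out within the scatter. Within the data shown here, the other new step, a 2.5-fold lower number from compound 1 to compound 3 (0.39 log units; beyond the scatter), is modest but is the first at this position to pass the scatter, and it separates 4-chlorophenyl from 1H-benzimidazol-2-yl, while naphthalen-2-yl stays within the scatter of both. No measurement at hand gives a reason for either step.

Open, from the compounds shown here alone, is what the chlorine itself contributes, a question that a plain phenyl or a 4-methoxyphenyl on this sulfur would address. Also open, going by these compounds, is how an amine or a carboxylic acid on that ring, or a longer chain in place of the saturated chain carbon, would read in this assay.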